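Carboxymethyl ether of a diyne alcohol: expected cytotoxicity

This account rests on a few compounds, and the source may have more. Where it says the series, first, only, none or still open, it means among the compounds named here.

Two diyne compounds have been measured so far. Compound 1 `C=CCCCCCCCC#CC#CCOCC(=O)O` gives 4.47 ug/mL in a functional assay on HCT-15 cells (Homo sapiens) for cytotoxicity; on this read-out lower numbers stand for an effect already at smaller amounts and higher numbers for an effect only at larger amounts of compound. Compound 2 `CCCCCCCC#CC#CCO` carries a free hydroxy group and gives 5.9 ug/mL in this assay, the higher of the two numbers; compound 1 lies within the usual scatter of compound 2, so the two values show no real separation.

Compound 3 `CCCCCCCC#CC#CCOCC(=O)O` has not yet been measured. It differs from compound 2 in one place: carboxymethyl in place of hydrogen on an oxygen on a saturated carbon.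

Among the compounds with values here, with no measured pair that shares this change, the expectation rests on compound 1, whose value of 4.47 ug/mL already shows that a carboxymethoxy-bearing diyne stays in the same range as the alcohol. Compound 3 is therefore expected to give about 5 ug/mL in this assay, between 2 ug/mL and 12 ug/mL. The estimated step of a 1.2-fold lower number from compound 2 to compound 3 (0.07 log units; within the scatter) is expected to be none beyond the scatter.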

Compound 3, concentration for half-maximal effect: 8.3 ug/mL
The estimate for compound 3 lay 1.7-fold (0.22 log units) below the measured number; low and high end bracket the measured number.
By their numbers in this assay, from the lowest: compounds 1, 2 and 3 (each within the scatter of the next).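

Within the data shown here, compound 3 gives the first direct reading of this change: in this assay, carboxymethyl in place of hydrogen on an oxygen on a saturated carbon comes with a 1.4-fold higher number from compound 2 to compound 3 (0.15 log units; within the scatter), so on this diyne chain hydroxy and carboxymethoxy are not told apart. The other end of the molecule reads the same way, as hydrogen in place of vinyl on a saturated chain carbon, seven bonds along the chain from a triple-bonded carbon, comes with a 1.9-fold higher number from compound 1 to compound 3 (0.27 log units; within the scatter). No independent data are available to explain either result.

The compounds shown leave open whether an amine or an amide on this oxygen would give a number beyond the scatter. They also leave open whether a longer chain would do so.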